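Moving the carboxylic acid around the ring

The source may hold more compounds than are shown below. What is called first, only, known or untested is meant among the compounds shown, and "the series" means these compounds.

Measured so far:
- compound 1, `O=C(O)c1ccc(C2CCCN2C(=O)C(Nc2ccccc2F)c2ccc(C(F)(F)F)cc2)cc1`: 66 nM
- compound 2, `O=C(O)c1cccc(C2CCCN2C(=O)C(Nc2ccccc2F)c2cc3ccccc3s2)c1`: 78 nM

In an assay on HEK293 cells for antagonist activity at transient receptor potential M8 protein (Canis lupus familiaris), read by fluorescence and calcium flux, with a stated time of 5 min (on this read-out higher numbers stand for weaker inhibition and lower numbers for stronger inhibition), compound 1 gives 66 nM and compound 2 gives 78 nM. Compound 2 carries the highest of the two numbers, but its gap to compound 1 lies within the scatter, so the two are best read as equal. The two compounds differ in more than one place, so nothing can be said about any single change between them.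

Compound 3, `O=C(O)c1ccc(C2CCCN2C(=O)C(Nc2ccccc2F)c2cc3ccccc3s2)cc1`, is not yet measured. It keeps the rest of compound 2 and changes only the acid-bearing ring: 4-carboxyphenyl in place of 3-carboxyphenyl on a saturated ring carbon. Compound 1 already holds a 4-carboxyphenyl group and sits at 66 nM, close to compound 2, so no step beyond the scatter is expected from this change. Compound 3 is expected to come in at 60 nM, between 25 nM and 150 nM, a step of a 1.3-fold lower number from compound 2 to compound 3 (0.11 log units; within the scatter) that is estimated to lie within the scatter.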

Compound 3, half-maximal inhibitory concentration: 41 nM
Beside the measured number, compound 3's estimate is 1.5-fold (0.17 log units) above it; the range from low to high includes it.
By their numbers in this assay, from the lowest: compounds 3, 1 and 2 (each within the scatter of the next).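

In this assay, among these compounds, putting 4-carboxyphenyl in place of 3-carboxyphenyl on the saturated ring carbon gives a 1.9-fold lower number from compound 2 to compound 3 (0.28 log units; within the scatter) and is the first comparison here that changes the acid-bearing ring alone, so the two groups read as equal at this place. Putting 1-benzothiophen-2-yl in place of 4-(trifluoromethyl)phenyl on the saturated chain carbon gives a 1.6-fold lower number from compound 1 to compound 3 (0.21 log units; within the scatter) and also shows no change that can be told apart from repeat-measurement noise, here with 4-carboxyphenyl held fixed. No measurement at hand bears on why these values stay so close.

Still open, going by these compounds, is whether the carboxylic acid is needed at all, which an amide or a nitrile in its place would test. Also open, on these data alone, is what other groups on the saturated chain carbon, such as a plain phenyl or a cyclohexyl, would give.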